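The compounds below may be only part of what the source reports. "The series", "measured", "known", "first", "only" and "open" are said of these compounds alone.

Measured compounds in an assay for inhibition of Indoleamine 2,3-dioxygenase 1 (Homo sapiens), with stated times of 10 min and 60 min, tested at 10 uM; a higher number here means a stronger effect of the compound at the concentration tested, a lower number a weaker effect:
Compound 1, `Nc1cccc(CNc2cc(C(F)(F)F)cc3[nH]ncc23)c1`, gives 24%.
Compound 2, `Oc1ccc(CNc2cc(C(F)(F)F)cc3[nH]ncc23)cc1`, gives 37%.
Compound 3, `FC(F)(F)c1cc(NC[C@H]2CCCCN2)c2cn[nH]c2c1`, gives 19%.

On these numbers compound 3 stands lowest of the three. Its nearest neighbour is compound 1, a step of a number 5 percentage points lower from compound 1 to compound 3 (within the scatter), which lies within the scatter; its furthest is compound 2, a step of a number 18 percentage points lower from compound 2 to compound 3 (beyond the scatter), which lies beyond it. Compound 4, `FC(F)(F)c1cc(NC[C@H]2CCCN2)c2cn[nH]c2c1`, differs from compound 3 by pyrrolidin-2-yl in place of piperidin-2-yl on a saturated chain carbon bound to a nitrogen on an aromatic ring. For the measured compounds named here, neither measured step bears closely on this change: both exchange an aromatic group for another group at that place, and the one that reaches compound 3 is itself within the scatter. Compound 4 is therefore expected to show no step beyond the scatter, a number 1 percentage points higher from compound 3 to compound 4 (within the scatter). The estimate for compound 4 in this assay is 20%, ranging from 8% to 34%.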

Compound 4, a percentage reported as inhibition, at one concentration (the size of the read-out at that concentration, not a potency): 34%
For compound 4 the middle estimate is 14 percentage points below the measured one, and the stated range covers the measured number.
By their numbers in this assay, from the lowest: compounds 3, 1, 4 and 2 (each within the scatter of the next, the first and the last beyond it).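

In this assay, the change of saturated ring alone moves the read-out: pyrrolidin-2-yl in place of piperidin-2-yl gives a step beyond the scatter (a number 15 percentage points higher from compound 3 to compound 4 (beyond the scatter)). A saturated group at this place can also stand level with either aromatic group, as both remaining steps lie within the scatter (a number 3 percentage points lower from compound 2 to compound 4 (within the scatter); a number 10 percentage points higher from compound 1 to compound 4 (within the scatter)). Nothing measured here accounts for the difference between the two rings. From the compounds shown here alone, it remains open how an azetidin-2-yl ring, a morpholine ring or an open-chain amine would read at this place, and how the opposite stereocentre of pyrrolidin-2-yl would read.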